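The source may hold more compounds than are shown below. What is called first, only, known or untested is meant among the compounds shown, and "the series" means these compounds.

In a toxicity assay on KB cells (Homo sapiens) for cytotoxicity, read by fluorescence, with a stated time of 3 days (on this read-out higher numbers stand for an effect only at larger amounts of compound and lower numbers for an effect already at smaller amounts), compound 1 `CCCCOC(=O)CNC(=O)[C@H](CSc1ccc([N+](=O)[O-])cc1[N+](=O)[O-])NC(=O)CC[C@H](NC(=O)CC(C)C)C(=O)OCCCC` gives 59.6 uM, and compound 2 `CCCCOC(=O)CNC(=O)[C@H](CSc1ccc([N+](=O)[O-])cc1[N+](=O)[O-])NC(=O)CC[C@H](NC(=O)CC(C)(C)C)C(=O)OCCCC` gives 250 uM, which is a 4.2-fold higher number from compound 1 to compound 2 (0.62 log units; beyond the scatter). Compound 3 `CCCCOC(=O)CNC(=O)[C@H](CSc1ccc([N+](=O)[O-])cc1[N+](=O)[O-])NC(=O)CC[C@H](Nc1nc(N)nc(Cl)n1)C(=O)OCCCC` yields no number, only a limit of > 300 uM, and so sits at the limit of the assay, as in the limit of > 300 uM in this assay, at which 1 of the 3 values shown sits.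

Compound 4 `CCCCOC(=O)CNC(=O)[C@H](CSc1ccc([N+](=O)[O-])cc1[N+](=O)[O-])NC(=O)CC[C@H](N)C(=O)OCCCC` has hydrogen in place of 4-amino-6-chloro-1,3,5-triazin-2-yl on an amine nitrogen. The measured steps that bear on this are the exchanges on that same nitrogen. One is an at least 5.0-fold higher number from compound 1 to compound 3 (0.70 log units; beyond the scatter), beyond the scatter, and the other is an at least 1.2-fold higher number from compound 2 to compound 3 (0.07 log units; that floor lies within the scatter), whose floor lies within it. Among the compounds with values here, no compound with the free amine has been measured, so the reversal of these steps is only a guide. A modest move to a lower number in this assay is expected, similar in size to the first of these two steps. The expected change is an at least 4.2-fold lower number from compound 3 to compound 4 (0.63 log units; beyond the scatter). For compound 4 the estimated value is 70 uM. The estimated range for compound 4 runs from 15 uM to 300 uM.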

Compound 4, concentration for half-maximal effect: 107 uM
The estimate for compound 4 lay 1.5-fold (0.18 log units) below the measured number; measured number inside the range.
By their numbers in this assay, from the lowest: compounds 1 and 4 (each within the scatter of the next); then compound 2. At a limit, above all of these: compound 3.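

Taking the 4-amino-6-chloro-1,3,5-triazin-2-yl group off this amine nitrogen gives an at least 2.8-fold lower number from compound 3 to compound 4 (0.44 log units; beyond the scatter) in this assay and so places the free amine clearly under the triazine compound. Hydrogen on this nitrogen also gives a reference for the two acyl groups: a 2.3-fold lower number from compound 2 to compound 4 (0.37 log units; beyond the scatter) and a 1.8-fold higher number from compound 1 to compound 4 (0.25 log units; within the scatter) mean that neopentylcarbonyl stands apart from hydrogen while isobutylcarbonyl does not. Compound 3 has only a limit and not a number, so the full size of the first step stays unread: the limit of > 300 uM in this assay, at which 1 of the 4 values shown sits.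

The compounds shown leave open how an acetyl group or a longer straight acyl chain on this nitrogen would read. They also leave open whether a triazine carrying a second amino group in place of the chlorine would stay at the limit.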